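The source may report more compounds than this note shows. Statements on the series, on what has been measured and on what is new or still open speak of the compounds shown alone.

Compound 3 `O=[N+]([O-])c1cc(-c2nnn(Cc3cccc(F)c3)n2)cc([N+](=O)[O-])c1` gives 315000 nM in an ADME assay on CHO-K1 cells (Cricetulus griseus) for cytotoxicity, read by MTT assay, with a stated time of 24 h (a higher number here means a weaker inhibitor, a lower number a stronger inhibitor), the highest of the three numbers measured, although compound 1 `O=[N+]([O-])c1cc(-c2nnn(Cc3ccc(Cl)cc3)n2)cc([N+](=O)[O-])c1` with 170000 nM lies within the scatter of it, the gap being a 1.9-fold higher number from compound 1 to compound 3 (0.27 log units; within the scatter). Compound 2 `O=[N+]([O-])c1cc(-c2nnn(Cc3ccc(Br)cc3)n2)cc([N+](=O)[O-])c1` gives 55000 nM, and the step of a 5.7-fold higher number from compound 2 to compound 3 (0.76 log units; beyond the scatter) is beyond the scatter, as is a 3.1-fold lower number from compound 1 to compound 2 (0.49 log units; beyond the scatter). Compound 4 `O=[N+]([O-])c1cc(-c2nnn(Cc3ccc(Cl)c(Cl)c3)n2)cc([N+](=O)[O-])c1` differs from compound 3 by 3,4-dichlorophenyl in place of 3-fluorophenyl on a saturated chain carbon bound to an aromatic nitrogen. The two steps into compound 3 show that exchanging a 4-chlorophenyl or a 4-bromophenyl for 3-fluorophenyl raised the number, so returning to a chlorine-bearing ring, now carrying two chlorines, is expected to lower it. The change is therefore expected to give a modest step, a 3.2-fold lower number from compound 3 to compound 4 (0.50 log units; beyond the scatter). Compound 4 is estimated at 100000 nM, with a range from 30000 nM to 300000 nM.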

Compound 4, half-maximal inhibitory concentration: 37000 nM
Estimate against measurement, compound 4: 2.7-fold (0.43 log units) above, and the stated range covers the measured number.
By their numbers in this assay, from the lowest: compounds 4 and 2 (each within the scatter of the next); then compounds 1 and 3 (each within the scatter of the next).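

In this assay, among these compounds, adding a chlorine to the ring gives a 4.6-fold lower number from compound 1 to compound 4 (0.66 log units; beyond the scatter) as the first step at this position that adds a halogen instead of exchanging one. Replacing 3-fluorophenyl gives an 8.5-fold lower number from compound 3 to compound 4 (0.93 log units; beyond the scatter) as the largest step seen so far, while a 1.5-fold lower number from compound 2 to compound 4 (0.17 log units; within the scatter) means that 3,4-dichlorophenyl and 4-bromophenyl cannot be told apart here. Nothing measured here explains these steps.

The compounds shown leave open how a ring carrying an amine or a carboxylic acid would read at this saturated chain carbon. They also leave open what a longer chain in place of this carbon would do.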